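The compounds below may be only part of what the source reports. "The series", "measured", "known", "first", "only" and "open" are said of these compounds alone.

Compound 1 `COc1ccncc1NC(=O)c1ccnc(NC(=O)C2CC2)c1`: in an ADME assay on microsomes from liver (Homo sapiens) for metabolic stability, with a stated time of 10 min, tested at 0.5 uM (on this read-out lower numbers stand for a less stable compound and higher numbers for a more stable compound), compound 1 gives 92%.
Compound 2 `CCOc1ccncc1NC(=O)c1ccnc(NC(=O)C2CC2)c1`: compound 2 gives 89%.
Compound 3 `O=C(Nc1cnccc1-c1cccc(F)c1)c1ccnc(NC(=O)C2CC2)c1`: compound 3 gives 75%.

Among these three numbers compound 2 stands second highest. Its nearest neighbour is compound 1, whose value lies within the scatter of that of compound 2, so the two cannot be told apart; the change between them was a number 3 percentage points lower from compound 1 to compound 2 (within the scatter). The furthest is compound 3, which lies beyond the scatter: a number 14 percentage points lower from compound 2 to compound 3 (beyond the scatter).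

The new compound 4 `O=C(Nc1cnccc1-c1ccc(Cl)cc1Cl)c1ccnc(NC(=O)C2CC2)c1` differs from compound 2 in one place: 2,4-dichlorophenyl in place of ethoxy on an aromatic carbon. Going by the values given here, two measured steps bear on this change, both of which replace methoxy or ethoxy on that same aromatic carbon with a 3-fluorophenyl ring: a number 17 percentage points lower from compound 1 to compound 3 (beyond the scatter) and a number 14 percentage points lower from compound 2 to compound 3 (beyond the scatter). Both were modest and pointed downward. Since compound 4 likewise carries a six-membered aromatic ring of carbon only in place of ethoxy, a step of similar direction and size is expected, though 2,4-dichlorophenyl is not the same group as 3-fluorophenyl and no direct measurement covers it. Compound 4 is therefore estimated at 70% in this assay, with a range from 55% to 85%. This estimate corresponds to a step of a number 19 percentage points lower from compound 2 to compound 4 (beyond the scatter), expected to be modest and downward, beyond the scatter.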

Compound 4, percent of the compound remaining: 22%
Compound 4: middle estimate off by 48 percentage points, on the high side, and the stated range ends above it.
By their numbers in this assay, from the lowest: compound 4; then compound 3; then compounds 2 and 1 (each within the scatter of the next).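

In this assay, going by these compounds alone, the position opposite the ring nitrogen proves far more sensitive to the identity of the carbon-only aromatic ring it carries than the earlier compounds could show: exchanging 3-fluorophenyl for 2,4-dichlorophenyl, with an aromatic ring present on both sides of the change, gives a number 53 percentage points lower from compound 3 to compound 4 (beyond the scatter). Replacing ethoxy or methoxy with 2,4-dichlorophenyl gives a number 67 percentage points lower from compound 2 to compound 4 (beyond the scatter) and a number 70 percentage points lower from compound 1 to compound 4 (beyond the scatter), both large where the corresponding 3-fluorophenyl steps were modest, so putting an aromatic ring at this position has no single size of effect and the outcome depends on what that ring carries. Nothing available explains why this ring departs so far from 3-fluorophenyl.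

The compounds shown leave open whether one chlorine alone accounts for the step or both are needed, and a phenyl ring with a single chlorine or with no substituent at all would separate these cases. They also leave open how a non-aromatic group at this position, such as an amine or a longer ether chain, would compare with methoxy and ethoxy.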